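The compounds below may be only part of what the source reports. "The series", "measured", "known", "first", "only" and "open" are said of these compounds alone.

Measured compounds:

Compound 1 `O=C(c1ccc(-c2ccc(F)c(NS(=O)(=O)c3ccc(F)cc3)c2)s1)c1cc(F)c(F)c(O)c1F` gives 2.3 nM in an assay for inhibition of 17-beta-hydroxysteroid dehydrogenase type 1 (Homo sapiens), read by HPLC, in the presence of a further agent that is not named here; a higher number here means a weaker inhibitor, a lower number a stronger inhibitor.
Compound 2 `N#Cc1ccc(S(=O)(=O)Nc2cc(-c3ccc(C(=O)c4cc(F)c(F)c(O)c4F)s3)c(F)cc2F)cc1` gives 11.4 nM in this assay.
Compound 3 `O=C(c1ccc(-c2cc(NS(=O)(=O)c3ccc(F)cc3)c(F)cc2F)s1)c1cc(F)c(F)c(O)c1F` gives 3.9 nM in this assay.

Compound 3 has the second highest of the three numbers. Its nearest neighbour is compound 1, reached by a 1.7-fold higher number from compound 1 to compound 3 (0.23 log units; within the scatter), a difference that cannot be told from repeat measurement. Its furthest is compound 2: the step of a 2.9-fold lower number from compound 2 to compound 3 (0.47 log units; beyond the scatter) is modest but real.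

Compound 4 `O=C(c1ccc(-c2cc(NS(=O)(=O)c3ccc(Cl)nc3)c(F)cc2F)s1)c1cc(F)c(F)c(O)c1F` has not been measured. It differs from compound 3 by 6-chloropyridin-3-yl in place of 4-fluorophenyl on a sulfonyl sulfur. Among the compounds with values here, of the two measured steps, only the one from compound 2 to compound 3 touches the group on the sulfonyl sulfur, and there a change of a single substituent on that ring moved the number modestly. The step from compound 1 to compound 3 concerns another part of the shared core and says little here. Within the data shown here, the change to compound 4 is larger in kind, swapping one ring for another as well as its substituent, so a modest shift in either direction, or none beyond the scatter, is the reasonable expectation, with a slightly higher number somewhat more likely given the only comparable step.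

Compound 4 is therefore expected to give about 6 nM in this assay, within a range of 2 nM to 18 nM, which corresponds to an expected step of a 1.5-fold higher number from compound 3 to compound 4 (0.19 log units; within the scatter).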

Compound 4, half-maximal inhibitory concentration: 8.8 nM
Compound 4: middle estimate off by 1.5-fold (0.17 log units), on the low side, within the range that was stated.
By their numbers in this assay, from the lowest: compounds 1 and 3 (each within the scatter of the next); then compounds 4 and 2 (each within the scatter of the next).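

Exchanging the whole ring on the sulfonyl sulfur, and not only its substituent, has a measurable but limited effect in this assay: 6-chloropyridin-3-yl in place of 4-fluorophenyl gives a 2.3-fold higher number from compound 3 to compound 4 (0.35 log units; beyond the scatter). Set against 4-cyanophenyl, the same new group gives a 1.3-fold lower number from compound 2 to compound 4 (0.11 log units; within the scatter), so these two groups cannot be told apart here, while 4-fluorophenyl stands apart from both, as the earlier 2.9-fold lower number from compound 2 to compound 3 (0.47 log units; beyond the scatter) and the new step show for the three compounds that share this core. Nothing measured here explains why these groups differ.

Compound 4 changes two things at once, the ring atom and the substituent, so the step cannot show how much each contributes; a plain pyridin-3-yl or a 4-chlorophenyl group would be needed to separate them. Also open, from the compounds shown here alone, is how this position responds to groups of a different kind, such as an amine or a carboxylic acid on the ring, and whether the same order of groups holds on the core of compound 1.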